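The source may hold more compounds than are shown below. What is called first, only, known or untested is meant among the compounds shown, and "the series" means these compounds.

Measured so far:
- compound 1, `COc1ccc(-c2nc(C)c(C(=O)CSc3nc(-c4ccc(Cl)cc4)c(C#N)c(=O)[nH]3)s2)cc1`: 48%
- compound 2, `Cc1nc(-c2ccc(Cl)cc2)sc1C(=O)CSc1nc(-c2cccc(Cl)c2)c(C#N)c(=O)[nH]1`: 52.6%
- compound 3, `COc1ccc(-c2nc(C)c(C(=O)CSc3nc(-c4ccc(Cl)c(Cl)c4)c(C#N)c(=O)[nH]3)s2)cc1`: 78.4%

All three were tested in a functional assay on U-87MG ATCC cells for antiproliferative activity against U-87 MG (Homo sapiens), read by MTT assay, with a stated time of 48 h, tested at 50 uM; a lower number here means a stronger effect, a higher number a weaker effect of the compound at the concentration tested. Compound 3 stands highest of the three numbers in this assay, and both gaps lie beyond the scatter: compound 2 is nearer, compound 1 furthest. Going by the values given here, the one step that can be traced through a single change is a number 30.4 percentage points higher from compound 1 to compound 3 (beyond the scatter), a large rise when a chloro group joins the phenyl ring.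

Compound 4, `COc1ccc(-c2nc(C)c(C(=O)CSc3nc(-c4cccc(Cl)c4)c(C#N)c(=O)[nH]3)s2)cc1`, differs from compound 3 by hydrogen in place of chloro on an aromatic carbon. This is the removal of a chloro group, the same kind of change that the step from compound 1 to compound 3 showed in reverse, though the chloro removed here sits at a different spot on the ring. Compound 2 also carries a 3-chlorophenyl group, on a core with a different outer ring, and gives a much lower number than compound 3. Taken together, a step downward in this assay is expected for compound 4, of about a number 26.4 percentage points lower from compound 3 to compound 4 (beyond the scatter). Compound 4 is therefore estimated at 52%, with a likely range from 38% to 68%.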

Compound 4, a percentage reported as activity, at one concentration (the size of the read-out at that concentration, not a potency): 83.4%
The estimate for compound 4 lay 31.4 percentage points below the measured number; the whole stated range lies below it.
By their numbers in this assay, from the lowest: compounds 1 and 2 (each within the scatter of the next); then compounds 3 and 4 (each within the scatter of the next).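

In this assay the chloro that leaves the 3,4-dichlorophenyl group makes no readable difference, with a number 5 percentage points higher from compound 3 to compound 4 (within the scatter) as the whole step, so the second chloro on this ring is not what sets the number here. Among these compounds the place of the single chloro counts instead, with a number 35.4 percentage points higher from compound 1 to compound 4 (beyond the scatter) when 3-chlorophenyl takes the place of 4-chlorophenyl, and this reframes the earlier rise on adding a chloro to compound 1 as a rise that goes with the 3-chlorophenyl group. The 3-chlorophenyl group does not fix the number alone, with a number 30.8 percentage points higher from compound 2 to compound 4 (beyond the scatter) when methoxy replaces chloro on the other phenyl ring. No measurement offered here accounts for any of these steps.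

On this ring the compounds shown carry only chloro or hydrogen, so it stays open how a fluoro, a methyl or an amine in the same place would read. Whether the 4-chlorophenyl group also gives a lower number when the other phenyl ring carries chloro is open as well, as compound 2 has no partner that differs from it only in that way.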